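Aryl swap on the ring amide nitrogen of the core

The compounds below may be only part of what the source reports. "The series", "measured", "known", "first", "only" and "open" are said of these compounds alone.

Three compounds share one core and differ only in the aryl group on the ring amide nitrogen. In a functional assay on HEK293 cells for positive allosteric modulation of metabotropic glutamate receptor 5 (Homo sapiens), read by calcium flux (on this read-out higher numbers stand for larger maximal responses and lower numbers for smaller maximal responses), compound 1 `O=C1c2cc(COc3ccccc3)nn2CCN1c1cccc(F)c1` gives 81%, compound 2 `O=C1c2cc(COc3ccccc3)nn2CCN1c1ccc(F)cc1` gives 79%, and compound 3 `O=C1c2cc(COc3ccccc3)nn2CCN1c1ccc(F)c(F)c1` gives 81%. The steps among them are small: a number 2 percentage points lower from compound 1 to compound 2 (within the scatter), no change at the digits printed from compound 1 to compound 3 (within the scatter), and a number 2 percentage points higher from compound 2 to compound 3 (within the scatter). Compound 3 is level with compound 1 at the digits shown and sits together with it at the top of the three numbers, with compound 2 the furthest away, though no pair is separated beyond the scatter.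

Compound 4 `Cc1ccc(N2CCn3nc(COc4ccccc4)cc3C2=O)nc1` takes the next step: 5-methylpyridin-2-yl in place of 3,4-difluorophenyl on an amide-type nitrogen in a ring. As far as these compounds go, all three measured steps concern exchanges of the aryl group on this same ring nitrogen, and each stayed within the scatter; none of them introduces a ring with a hetero atom or a methyl group, so that part of the change is untested here. On the evidence at hand, the step is expected to stay within the scatter: a number 1 percentage points lower from compound 3 to compound 4 (within the scatter). Compound 4 is therefore estimated at 80%, with a range from 66% to 92%.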

Compound 4, largest response reached (Emax), in percent of the reference or control that the assay uses: 76%
The estimate for compound 4 lay 4 percentage points above the measured number; the range from low to high includes it.
By their numbers in this assay, from the lowest: compounds 4, 2, 1 and 3 (each within the scatter of the next).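

In this assay the aryl exchange on the ring amide nitrogen now reaches a ring with a hetero atom and a methyl group, and the reading stays within the scatter of all three earlier compounds: a number 5 percentage points lower from compound 3 to compound 4 (within the scatter) and a number 3 percentage points lower from compound 2 to compound 4 (within the scatter) and a number 5 percentage points lower from compound 1 to compound 4 (within the scatter). At this position, then, 5-methylpyridin-2-yl, which counts one hydrogen-bond acceptor where 3,4-difluorophenyl counts none, cannot be separated on this read-out from the fluorinated phenyl groups. No supporting data bear on this result.

The ring nitrogen and the methyl group enter together, so their separate contributions remain unresolved. Also open, as far as these compounds go, is whether an amine or a carboxylic acid on this aryl ring, or a longer chain in place of the methyl group, would stay within the scatter.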